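Trimming a benzimidazolylmethyl thioether down to propargyl

A few compounds are considered here, and "the series" means these few. Any claim that something is new, unique, unknown or untested is made for them only; others in the source may bear on it.

Of the compounds shown here, three on a shared core have been measured in an ADME assay on GES1 cells (Homo sapiens) for inhibition, read by MTT assay, with a stated time of 72 h; on this read-out lower numbers stand for stronger inhibition and higher numbers for weaker inhibition. Compound 1 `Cc1cc(Nc2ccn(Cc3cccc4ccccc34)n2)n2nc(SCc3ccc(Br)cc3)nc2n1` gives 30000 nM, and compound 3 `Cc1cc(Nc2ccn(Cc3ccccc3)n2)n2nc(SCc3ccc(Br)cc3)nc2n1` gives 44400 nM. Within the data shown here, the single step recorded between them, a 1.5-fold higher number from compound 1 to compound 3 (0.17 log units; within the scatter), changes a group on a saturated chain carbon bound to an aromatic nitrogen. Compound 2 `Cc1cc(Nc2cc(-c3ccccc3)[nH]n2)n2nc(SCc3nc4ccccc4[nH]3)nc2n1` gives 27800 nM; its gaps to compound 1 and to compound 3 are both within the scatter, so compound 2 stands among the other two without separation, and all three show only weak inhibition in this assay.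

Compound 4 `C#CCSc1nc2nc(C)cc(Nc3cc(-c4ccccc4)[nH]n3)n2n1` is not yet measured. It differs from compound 2 in one place: ethynyl in place of 1H-benzimidazol-2-yl on a saturated chain carbon bound to a sulfur. Among the measured compounds shown here, no measured step touches the group on the sulfur-bound chain carbon; the only recorded step, a 1.5-fold higher number from compound 1 to compound 3 (0.17 log units; within the scatter), sits elsewhere and lies within the scatter. For the measured compounds named here, with no step bearing on this position, and with every measured number clustered in the same weak range, he expects no change beyond the scatter for compound 4, a step of a 1.3-fold higher number from compound 2 to compound 4 (0.10 log units; within the scatter). His estimate for compound 4 in this assay is 35000 nM, with a range from 15000 nM to 80000 nM.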

Compound 4, half-maximal inhibitory concentration: 45700 nM
Beside the measured number, compound 4's estimate is 1.3-fold (0.12 log units) below it; measured number inside the range.
By their numbers in this assay, from the lowest: compounds 2, 1, 3 and 4 (each within the scatter of the next).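

Among these compounds, the step at this position, a 1.6-fold higher number from compound 2 to compound 4 (0.22 log units; within the scatter), is the first measured at a saturated chain carbon bound to a sulfur, and in this assay it spans a large structural difference. 1H-benzimidazol-2-yl, with 9 heavy atoms, two aromatic rings, 1 hydrogen-bond donor and 1 hydrogen-bond acceptor, gives way to ethynyl, with 2 heavy atoms, no ring and 0 hydrogen-bond donors or acceptors, yet the two numbers cannot be told apart in this read-out. For this one pair, the benzimidazole rings and their donor and acceptor are therefore not needed to keep the number where it stands, and no available evidence accounts for this result.

The compounds shown leave open whether an amine or a carboxylic acid on this sulfur-bound chain carbon, or a longer chain in place of propargyl, would also stay within the scatter of compound 2. Among the compounds shown here, they also leave open whether ethynyl in place of 4-bromophenyl would read the same way on the pyrazole-bearing partners of compound 1 and compound 3, since this position has been compared on only one pair.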